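Spiroimidazolone glucagon antagonists: aryl swap at the imine carbon

The source may hold more compounds than are shown below. What is called first, only, known or untested is meant among the compounds shown, and "the series" means these compounds.

Three compounds of the series have numbers in a functional assay on CHO cells for antagonist activity at Glucagon receptor (Homo sapiens), read by cAMP accumulation, with stated times of 30 min and 45 min; a lower number here means a stronger inhibitor, a higher number a weaker inhibitor. Compound 1 `CC(C)(C)CC[C@H](c1ccc(C(=O)NCc2nn[nH]n2)cc1)N1C(=O)C(c2cncc(Cl)c2)=N[C@]12CC[C@@H](C(C)(C)C)CC2` gives 480 nM, compound 2 `C[C@H](c1ccc(C(=O)NCCC(=O)O)cc1)N1C(=O)C(c2ccccc2F)=N[C@]12CC[C@@H](C(C)(C)C)CC2` gives 350 nM and compound 3 `CC(C)(C)[C@H]1CC[C@]2(CC1)N=C(c1ccc(OC(F)(F)F)cc1)C(=O)N2Cc1ccc(C(=O)NCCC(=O)O)cc1` gives 1900 nM. Compound 1 holds the second highest of the three numbers; its gap to compound 2 lies within the scatter, whereas compound 3 sits beyond the scatter at the higher, weaker end. Compound 4 `CC(C)(C)CC[C@H](c1ccc(C(=O)NCc2nn[nH]n2)cc1)N1C(=O)C(c2cccc(C(F)(F)F)c2)=N[C@]12CC[C@@H](C(C)(C)C)CC2` differs from compound 1 in one place: 3-(trifluoromethyl)phenyl in place of 5-chloropyridin-3-yl on a carbon with a double bond to nitrogen. Among the measured compounds shown here, no measured pair shows the same change, so any step in this assay is a guess. The step from compound 1 to compound 4 is expected to be small, a 1.4-fold higher number from compound 1 to compound 4 (0.13 log units; within the scatter), leaning toward a higher number. Compound 4 is expected near 650 nM, in the range 200 nM to 2100 nM.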

Compound 4, half-maximal inhibitory concentration: 180 nM
For compound 4 the middle estimate is 3.6-fold (0.56 log units) above the measured one; the measured number lies below the stated range.
By their numbers in this assay, from the lowest: compounds 4, 2 and 1 (each within the scatter of the next, the first and the last beyond it); then compound 3.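

Among the compounds shown here, this is the first readable step at the carbon with a double bond to nitrogen: in this assay, 3-(trifluoromethyl)phenyl in place of 5-chloropyridin-3-yl gives a 2.7-fold lower number from compound 1 to compound 4 (0.43 log units; beyond the scatter). The number at this position therefore responds to the aryl group, and a ring of carbon only, without a hydrogen-bond acceptor, does not cost activity on the core of compound 1. No measurement at hand accounts for the step. As far as these compounds go, whether the lost ring nitrogen or the exchange of chlorine for trifluoromethyl drives it stays open. A 3-chlorophenyl group on the same core would separate the two.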